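Urea to amide on the shared core: an estimate

The source may report more compounds than this note shows. Statements on the series, on what has been measured and on what is new or still open speak of the compounds shown alone.

The compounds measured so far:
compound 1, `CCCNC(=O)Nc1c(OCCCn2cnc(-c3ccccc3)c2)cccc1N(C)C`, 7230 nM
compound 2, `CN(C)c1cccc(OCCCn2cnc(-c3ccccc3)c2)c1NC(=O)NC1CCCC1`, 3530 nM

Of the compounds shown here, two have been measured in an assay on aorta for inhibition of acyl-CoA:cholesterol acyltransferase (Oryctolagus cuniculus); on this read-out lower numbers stand for stronger inhibition and higher numbers for weaker inhibition. Within the data shown here, compound 1, `CCCNC(=O)Nc1c(OCCCn2cnc(-c3ccccc3)c2)cccc1N(C)C`, gives 7230 nM in this assay, the higher of the two numbers recorded; the only neighbour is compound 2, `CN(C)c1cccc(OCCCn2cnc(-c3ccccc3)c2)c1NC(=O)NC1CCCC1`, with 3530 nM. Among the measured compounds shown here, the single step between them, a 2.0-fold lower number from compound 1 to compound 2 (0.31 log units; beyond the scatter), is a modest one and replaces propyl with cyclopentyl on an amide-type nitrogen.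

Compound 3, `CCCCCC(=O)Nc1c(OCCCn2cnc(-c3ccccc3)c2)cccc1N(C)C`, has not been measured. It differs from compound 1 in one place: pentyl in place of propylamino on a carbonyl carbon. The urea of compound 1 thus becomes an amide carrying a five-carbon chain. For the measured compounds named here, no measured pair speaks directly to this exchange; the one step on record concerns a different position and was modest in size, so it offers only a loose guide to what the carbonyl substituent tolerates.

Given no direct precedent, compound 3 is expected to lie close to compound 1, with a step of about a 1.3-fold lower number from compound 1 to compound 3 (0.12 log units; within the scatter), no larger than what the modest step already seen suggests. The estimate for compound 3 in this assay is 5500 nM, within a range from 2000 nM to 15000 nM.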

Compound 3, half-maximal inhibitory concentration: 100 nM
Estimate against measurement, compound 3: 55-fold (1.74 log units) above, and the stated range ends above it.
By their numbers in this assay, from the lowest: compound 3; then compound 2; then compound 1.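

In this assay the group on the carbonyl carbon matters far more than the earlier pair could show: pentyl in place of propylamino gives a 72-fold lower number from compound 1 to compound 3 (1.86 log units; beyond the scatter) and pentyl in place of cyclopentylamino gives a 35-fold lower number from compound 2 to compound 3 (1.55 log units; beyond the scatter) on this position. Both steps are large, while the exchange of propyl for cyclopentyl on the amide-type nitrogen, a 2.0-fold lower number from compound 1 to compound 2 (0.31 log units; beyond the scatter) in that pair, is modest, so among these three compounds the move from urea to amide shifts the number much further than the choice between those two urea substituents. The change swaps the nitrogen and its hydrogen-bond donor and alters the chain at the same time, and no supporting data bear on the origin of the drop.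

The compounds shown do not separate these two parts of the change: a pentylamino group on the carbonyl carbon would test the nitrogen at matched chain length, while a propyl or heptyl chain there would test the length of the chain within the amide series. Going by these compounds, whether a cyclopentyl group directly on the carbonyl carbon would match pentyl also remains open.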